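The source may report more compounds than this note shows. Statements on the series, on what has been measured and on what is new or still open speak of the compounds shown alone.

Of the compounds shown here, three of a shared core have been measured in a functional assay on HepG2 cells (Homo sapiens) for antiproliferative activity, read by CCK-8 assay, with a stated time of 72 h (a lower number here means a stronger inhibitor, a higher number a weaker inhibitor), and each carries a different ring on the carbonyl carbon of the amide. Compound 1 `COc1cc(C(=O)Nc2ccc(C(=O)/C=C/c3nc(C)c(C)nc3C)cc2)cc(OC)c1OC` bears a 3,4,5-trimethoxyphenyl group there, and in this assay compound 1 gives 4860 nM. Compound 2 `COc1cccc(OC)c1C(=O)Nc1ccc(C(=O)/C=C/c2nc(C)c(C)nc2C)cc1` carries a 2,6-dimethoxyphenyl group, and in this assay compound 2 gives 3380 nM. Compound 3 `Cc1nc(C)c(/C=C/C(=O)c2ccc(NC(=O)c3ccccc3)cc2)nc1C` carries a plain phenyl group, and in this assay compound 3 gives 1310 nM, the lowest number of the three; the step of a 2.6-fold lower number from compound 2 to compound 3 (0.41 log units; beyond the scatter) lies beyond the scatter, and the gap between compound 1 and compound 3 is wider still.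

Compound 4 `COc1cc(OC)cc(C(=O)Nc2ccc(C(=O)/C=C/c3nc(C)c(C)nc3C)cc2)c1` is the next member: the change is 3,5-dimethoxyphenyl in place of phenyl on a carbonyl carbon. Among the compounds with values here, no measured step matches this exactly, but the only step bearing on it, a 2.6-fold lower number from compound 2 to compound 3 (0.41 log units; beyond the scatter), shows that taking two methoxy groups off this ring lowered the number, and compound 1 with three methoxy groups gives the highest number of all. Putting two methoxy groups back, though at different positions, is therefore expected to move the number upward, roughly as a 2.3-fold higher number from compound 3 to compound 4 (0.36 log units; beyond the scatter). Compound 4 is estimated at 3000 nM, with a range from 1300 nM to 7000 nM.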

Compound 4, half-maximal inhibitory concentration: 11000 nM
Estimate against measurement, compound 4: 3.7-fold (0.56 log units) below; measured number above the stated range.
By their numbers in this assay, from the lowest: compound 3; then compounds 2 and 1 (each within the scatter of the next); then compound 4.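

In this assay, placing methoxy groups on this ring does not just nudge the number upward: replacing the phenyl on the carbonyl carbon with 3,5-dimethoxyphenyl gives an 8.4-fold higher number from compound 3 to compound 4 (0.92 log units; beyond the scatter), and changing only where the two methoxy groups sit gives a 3.3-fold higher number from compound 2 to compound 4 (0.51 log units; beyond the scatter). Within the data shown here, the count of methoxy groups alone therefore does not set the number, since removing one methoxy group from the ring of compound 1 raises the number rather than lowering it, as a 2.3-fold higher number from compound 1 to compound 4 (0.35 log units; beyond the scatter) shows, and this goes against the simple reading from the earlier compounds that fewer methoxy groups mean a lower number. Nothing measured here explains why these changes act as they do.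

Of the rings shown, the plain phenyl of compound 3 still gives the lowest number, so it remains open whether any substituent on this ring can bring the number below that of compound 3. A single methoxy group, a fluorine, an amine or a carboxylic acid on this ring would each test that question, and the compounds shown say nothing about how such groups would behave.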